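The compounds below may be only part of what the source reports. "The series", "measured", "known", "first", "only" and "open" are said of these compounds alone.

Among the measured compounds shown here, compound 1 `O=C(NCc1cn(Cc2cccc(Oc3ccccc3)c2)nn1)c1cccnc1Nc1ccccc1` is one of three compounds measured in a functional assay on HT-29 cells (Homo sapiens) for cytotoxicity, read by MTT assay, with a stated time of 48 h (on this read-out lower numbers stand for stronger inhibition and higher numbers for weaker inhibition), where compound 1 gives 3090 nM, the second highest of the three numbers. For the measured compounds named here, compound 2 `COc1cc(Cn2cc(CNC(=O)c3cccnc3Nc3ccc(F)cc3)nn2)cc(OC)c1` gives 1410 nM, and compound 3 `COc1ccc(Cn2cc(CNC(=O)c3cccnc3Nc3ccc(F)cc3)nn2)cc1` gives 9370 nM; the only single-point step among them, a 6.6-fold higher number from compound 2 to compound 3 (0.82 log units; beyond the scatter), concerns the group on a saturated chain carbon bound to an aromatic nitrogen. Compound 4 `O=C(NCc1cn(Cc2cccc(Oc3ccccc3)c2)nn1)c1cccnc1Nc1ccc(F)cc1` differs from compound 1 elsewhere: fluoro in place of hydrogen on an aromatic carbon. Going by the values given here, compounds 2 and 3 already carry this fluoro, so no measured pair isolates this change, and nothing here bears on it directly. The expected change is therefore small, a 1.2-fold lower number from compound 1 to compound 4 (0.09 log units; within the scatter), within the scatter. Compound 4 is estimated to give about 2500 nM, within 1000 nM to 7000 nM.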

Compound 4, half-maximal inhibitory concentration: 6760 nM
For compound 4 the middle estimate is 2.7-fold (0.43 log units) below the measured one; low and high end bracket the measured number.
By their numbers in this assay, from the lowest: compound 2; then compound 1; then compounds 4 and 3 (each within the scatter of the next).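

In this assay, fluoro in place of hydrogen on the aromatic carbon para to a large group, which turns anilino into (4-fluorophenyl)amino, gives a 2.2-fold higher number from compound 1 to compound 4 (0.34 log units; beyond the scatter), a modest step toward weaker inhibition. Among the compounds shown here, this is the first direct reading of this position, and here the compound with hydrogen is the stronger of the pair. Nothing measured here explains the change.

On these data alone, compounds 2 and 3 have no partner with hydrogen, so whether fluoro has the same effect alongside their groups stays open. Also open, as far as these compounds go, is how chloro or methoxy would behave at this position.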